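This account rests on a few compounds, and the source may have more. Where it says the series, first, only, none or still open, it means among the compounds named here.

Measured so far in an ADME assay on microsomes from liver (Mus musculus) for metabolic stability, read by LC-MS, with a stated time of 40 min, tested at 0.5 uM; a higher number here means faster removal of the compound, a lower number slower removal:
compound 1, `O=C(Nc1cccc(S(=O)(=O)C2CCCC2)n1)c1ccc(NCCO)cc1N1CCC2(CC1)CC2`, gives > 399 mL.min-1.g-1, a limit of the assay.
compound 2, `O=C(Nc1cccc(S(=O)(=O)N2CCCC2)c1)c1cccnc1N1CCC2(CC1)CC2`, gives > 399 mL.min-1.g-1, a limit of the assay.
compound 3, `CC(C)(O)CNc1ccc(C(=O)Nc2cccc(S(=O)(=O)C3CCCC3)n2)c(N2CCC3(CC2)CC3)c1`, gives > 399 mL.min-1.g-1, a limit of the assay.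

Compound 2 therefore stands at the top limit of this assay rather than at a number, and the two other values shown are limits as well: the limit of > 399 mL.min-1.g-1 in this assay, at which 3 of the 3 values shown sit. Among the measured compounds shown here, the only one-place step among the measured compounds, a step that the two limits leave unreadable from compound 1 to compound 3, runs between two limits and gives no readable size, so nothing here tells how large a change in this assay a single substituent swap can produce.

Compound 4 is `O=C(Nc1cccc(S(=O)(=O)C2CCCC2)c1)c1cccnc1N1CCC2(CC1)CC2`. It differs from compound 2 in one place: cyclopentyl in place of pyrrolidin-1-yl on a sulfonyl sulfur. No measured step carries this change, and the one step that is shown, from compound 1 to compound 3, cannot be read; the expectation for compound 4 rests only on the fact that all three measured values sit at the limit, so a step that the limit leaves unreadable from compound 2 to compound 4 is expected to show no step beyond the scatter, with compound 4 most likely returned as a limit again. Compound 4 is estimated at 450 mL.min-1.g-1 in this assay, with a range from 200 mL.min-1.g-1 to 1000 mL.min-1.g-1.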

Compound 4, intrinsic clearance in microsomes: > 399 mL.min-1.g-1
Compound 4 gave a limit, no number; the forecaster's own chance of this, stated with the estimate: 80%; the middle value is on the limit's open side.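

In this assay compound 4 gives > 399 mL.min-1.g-1, a limit of the assay. Compound 2 sits at the same limit, so cyclopentyl in place of pyrrolidin-1-yl on a sulfonyl sulfur gives no readable step between compound 2 and compound 4. The compounds shown leave open what size of change a single swap can produce: the limit of > 399 mL.min-1.g-1 in this assay, at which 4 of the 4 values shown sit.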